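A few compounds are considered here, and "the series" means these few. Any claim that something is new, unique, unknown or untested is made for them only; others in the source may bear on it.

Three hydrazones share one core and differ only in the aryl group on the carbon with a double bond to nitrogen. Compound 1 `Cc1nc2cc(C(=O)N/N=C\c3ccco3)c([N+](=O)[O-])cc2[nH]1` carries furan-2-yl. In a functional assay on A549 cells (Homo sapiens) for cytotoxicity, read by resazurin assay, with a stated time of 72 h (on this read-out higher numbers stand for weaker inhibition and lower numbers for stronger inhibition), compound 1 gives only a limit of the assay, > 100000 nM. Compound 2 `Cc1nc2cc(C(=O)N/N=C\c3ccccn3)c([N+](=O)[O-])cc2[nH]1` carries pyridin-2-yl. In this assay compound 2 also gives only a limit, > 100000 nM. Compound 3 `Cc1nc2cc(C(=O)N/N=C\c3c[nH]c4ccccc34)c([N+](=O)[O-])cc2[nH]1` carries 1H-indol-3-yl. In this assay compound 3 likewise gives only a limit, > 100000 nM. Compound 3 therefore stands where the other two stand, at the limit of > 100000 nM in this assay, at which 3 of the 3 values shown sit, and none of the three can be ordered against another.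

Compound 4 `Cc1ccc(/C=N\NC(=O)c2cc3nc(C)[nH]c3cc2[N+](=O)[O-])cc1` is the next member. It differs from compound 3 by 4-methylphenyl in place of 1H-indol-3-yl on a carbon with a double bond to nitrogen. The measured steps that bear on such a swap of the aryl group are a step that the two limits leave unreadable from compound 1 to compound 2, a step that the two limits leave unreadable from compound 1 to compound 3 and a step that the two limits leave unreadable from compound 2 to compound 3, and each is unreadable because all of them rest on (the limit of > 100000 nM in this assay, at which 3 of the 3 values shown sit). For the measured compounds named here, no readable step is thus available, and the change from an indolyl to a tolyl group has no measured precedent here. The step from compound 3 to compound 4 is expected to be a step that the limit leaves unreadable from compound 3 to compound 4, most probably again hidden by the same limit. Compound 4 is estimated at 150000 nM in this assay, with a range from 40000 nM to 500000 nM.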

Compound 4, half-maximal inhibitory concentration: 73000 nM
Beside the measured number, compound 4's estimate is 2.1-fold (0.31 log units) above it; the measured number falls inside the stated range.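

In this assay, for the compounds shown here, compound 4 is the first member of the series to give a number rather than a limit, so a swap of the aryl group on a carbon with a double bond to nitrogen can now be read, if only in part. Against the three earlier compounds the result is an at least 1.3-fold lower number from compound 3 to compound 4 (0.13 log units; that floor lies within the scatter), an at least 1.3-fold lower number from compound 2 to compound 4 (0.13 log units; that floor lies within the scatter) and an at least 1.3-fold lower number from compound 1 to compound 4 (0.13 log units; that floor lies within the scatter), so 4-methylphenyl is not shown to differ from 1H-indol-3-yl, pyridin-2-yl or furan-2-yl by more than the usual scatter. The true size of these steps stays hidden because all three earlier compounds rest on a limit of the assay: the limit of > 100000 nM in this assay, at which 3 of the 4 values shown sit.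

The compounds shown leave open whether the number of compound 4 depends on the methyl group, which a plain phenyl, a 4-chlorophenyl or a 4-methoxyphenyl on the same carbon would test. They also leave open whether an amine in place of the nitro group on the shared core would shift the number in this assay.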